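Removing the chlorine from a prostacyclin receptor ligand

The source may hold more compounds than are shown below. What is called first, only, known or untested is meant among the compounds shown, and "the series" means these compounds.

The compounds here share a core in which two benzene rings are joined through a sulfur atom, with a cyclic guanidine-like group on one ring. Compound 3 `Clc1ccc(Sc2ccc(NC3=NCCN3)cc2)cc1` is measured in an assay (Rattus norvegicus) for binding affinity to prostacyclin receptor (Homo sapiens), read by radioligand binding (a higher number here means a weaker inhibitor, a lower number a stronger inhibitor), and gives 79.4 nM. For the measured compounds named here, its open-chain relative, compound 1 `CC/N=C(\N)Nc1ccc(Sc2ccc(Cl)cc2)cc1`, gives 631 nM in this assay, and the change a 7.9-fold lower number from compound 1 to compound 3 (0.90 log units; beyond the scatter) is the only step recorded here. Compound 2 `COc1ccc(Sc2ccc(NC3=NCCN3)cc2)cc1` carries a methoxy group where compound 3 carries chlorine; in this assay compound 2 gives 50.1 nM; 50.1 nM (2 entries), two readings that sit close to the number for compound 3. On the two single numbers available, compound 3 stands at the lower, stronger end.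

Compound 4 `c1ccc(Sc2ccc(NC3=NCCN3)cc2)cc1` differs from compound 3 by hydrogen in place of chloro on an aromatic carbon. Going by the values given here, no measured step touches this position directly. The step from compound 1 to compound 3 concerns a different part of the molecule and does not bear on it. The closeness of compound 2 and compound 3 suggests that this position tolerates different groups without large swings. The expectation for compound 4 is therefore a step of a 1.4-fold higher number from compound 3 to compound 4 (0.14 log units; within the scatter), which is within the scatter. Compound 4 is estimated at 110 nM, with a range from 40 nM to 300 nM.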

Compound 4, inhibition constant: 794 nM
Estimate against measurement, compound 4: 7.2-fold (0.86 log units) below; the whole stated range lies below it.
By their numbers in this assay, from the lowest: compound 3; then compounds 1 and 4 (each within the scatter of the next).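

In this assay, replacing chloro with hydrogen on this aromatic carbon gives a 10-fold higher number from compound 3 to compound 4 (1.00 log units; beyond the scatter), so the position is far from indifferent to what it carries. For the compounds shown here, the earlier readings showed only two substituted compounds, with chloro in compound 3 at 79.4 nM and methoxy in compound 2 at 50.1 nM; 50.1 nM (2 entries); they gave no view of the ring with no group there at all, and compound 4 now supplies that view at 794 nM, a number higher than either of the other two, which suggests that for these three compounds having either group here goes with a lower number than having hydrogen. No supporting information is available to explain why this change has such a large effect.

From the compounds shown here alone, what remains open is how far this link between a group at this position and a lower number extends, since only chloro and methoxy can be set against hydrogen here, and a fluorine atom, an amine, a carboxylic acid or a longer chain such as ethoxy could each fall anywhere relative to these values. It is also unknown whether the open-chain compound 1 would respond in the same way if its chloro were replaced with hydrogen.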